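This account rests on a few compounds, and the source may have more. Where it says the series, first, only, none or still open, it means among the compounds named here.

Measured so far in an assay on C3H 10T1/2 cells for inhibition of Sonic hedgehog protein (Mus musculus), read by a luciferase reporter; a higher number here means a weaker inhibitor, a lower number a stronger inhibitor:
compound 1, `Cc1nc(C(F)(F)F)ccc1C(=O)Nc1ccc(Cl)c(-c2cc3ccccc3[nH]2)c1`: 500 nM
compound 2, `Cc1nc(C(F)(F)F)ccc1C(=O)Nc1ccc(Cl)c(-n2cc3ccccc3n2)c1`: 80 nM

Among the compounds with values here, compound 2 stands lowest of the two numbers; the single step, a 6.3-fold lower number from compound 1 to compound 2 (0.80 log units; beyond the scatter), sets the gap to its only neighbour. Compound 3 is `Cc1nc(C(F)(F)F)ccc1C(=O)Nc1ccc(Cl)c(-c2ncccn2)c1`, not yet measured in this assay. Change: pyrimidin-2-yl in place of 2H-indazol-2-yl on an aromatic carbon. Within the data shown here, only the step from compound 1 to compound 2 bears on this change, and it exchanges one bicyclic group for another; the move to pyrimidin-2-yl also loses the six-membered aromatic ring of carbon only, which no measured step covers. A somewhat higher number for compound 3 is expected, a 3.8-fold higher number from compound 2 to compound 3 (0.57 log units; beyond the scatter). Compound 3 is estimated at 300 nM, range 80 nM to 1500 nM.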

Compound 3, half-maximal inhibitory concentration: 8000 nM
Compound 3: middle estimate off by 27-fold (1.43 log units), on the low side; the measured number lies above the stated range.
By their numbers in this assay, from the lowest: compound 2; then compound 1; then compound 3.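

In this assay the change to pyrimidin-2-yl on the aromatic carbon ortho to the chloro group gives a 100-fold higher number from compound 2 to compound 3 (2.00 log units; beyond the scatter) and a 16-fold higher number from compound 1 to compound 3 (1.20 log units; beyond the scatter) and so leaves compound 3 weaker than both compounds carrying a bicyclic group. This position is thus much less forgiving than the exchange of one bicyclic group for another showed. No measurement shown accounts for the rise.

From the compounds shown here alone, whether it follows the missing six-membered aromatic ring of carbon only or the ring nitrogens of pyrimidin-2-yl stays open. A plain phenyl or a pyridin-2-yl group here would separate the two.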